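The compounds below may be only part of what the source reports. "The series", "measured", "known", "first", "only" and "open" are said of these compounds alone.

Among the measured compounds shown here, compound 1 `O=C(/C=C/c1cccc(OCc2ccccc2)c1)c1ccc([N+](=O)[O-])cc1` in an ADME assay on HEK293 cells (Homo sapiens) for cytotoxicity, read by MTT assay, with a stated time of 68 h (on this read-out lower numbers stand for stronger inhibition and higher numbers for weaker inhibition), gives 59300 nM, the highest of the two numbers so far. Compound 2 `O=C(/C=C/c1cccc(OCc2ccccc2)c1)c1ccccc1` gives 14100 nM. For the measured compounds named here, the single measured step, a 4.2-fold lower number from compound 1 to compound 2 (0.62 log units; beyond the scatter), goes with hydrogen in place of nitro on an aromatic carbon. Compound 3 `COc1ccc(C(=O)/C=C/c2cccc(OCc3ccccc3)c2)cc1` differs from compound 1 by methoxy in place of nitro on an aromatic carbon. Going by the values given here, no measured step exchanges nitro for methoxy directly; the only step that bears on the change is the loss of the nitro group from compound 1 to compound 2, a 4.2-fold lower number from compound 1 to compound 2 (0.62 log units; beyond the scatter), which lowered the number beyond the scatter. Methoxy in place of nitro on an aromatic carbon is expected to give a step of comparable size in the same direction, towards a lower number, so a 4.0-fold lower number from compound 1 to compound 3 (0.60 log units; beyond the scatter) is expected. Compound 3 is therefore estimated at 15000 nM, with a range from 6000 nM to 40000 nM.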

Compound 3, half-maximal inhibitory concentration: 79800 nM
Estimate against measurement, compound 3: 5.3-fold (0.73 log units) below; the measured number lies above the stated range.
By their numbers in this assay, from the lowest: compound 2; then compounds 1 and 3 (each within the scatter of the next).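

In this assay, nitro and methoxy on the aromatic carbon para to a large group are not told apart (a 1.3-fold higher number from compound 1 to compound 3 (0.13 log units; within the scatter)), so the higher number of compound 1 relative to compound 2 is not peculiar to nitro. Methoxy in place of hydrogen gives a 5.7-fold higher number from compound 2 to compound 3 (0.75 log units; beyond the scatter), which matches in direction and lies close in size to the earlier step read the other way (a 4.2-fold lower number from compound 1 to compound 2 (0.62 log units; beyond the scatter)), leaving compound 2, with hydrogen at this place, apart from both substituted compounds. No measurement at hand explains this pattern.

From the compounds shown here alone, whether the lower number is specific to hydrogen remains open, since a smaller group such as fluorine, or an amine or a carboxylic acid, could fall on either side. The compounds shown also leave open whether methoxy would behave the same way at another place on this ring.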